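Carbamate chain variation in a selenocyanate series

The source may report more compounds than this note shows. Statements on the series, on what has been measured and on what is new or still open speak of the compounds shown alone.

Measured so far:
compound 1 `CC(C)COC(=O)Nc1ccc([Se]C#N)cc1`, 51200 nM
compound 2 `C=CCOC(=O)Nc1ccc([Se]C#N)cc1`, 50100 nM

In a functional assay on HTB-54 cells (Homo sapiens) for cytotoxicity, read by MTT assay, with a stated time of 72 h (a higher number here means a weaker inhibitor of growth, a lower number a stronger inhibitor of growth), compound 2 gives 50100 nM, the lower of the two numbers measured; compound 1, at 51200 nM, sits within the scatter of it, so no order between the two can be read. Compound 3 `CCCCCCOC(=O)Nc1ccc([Se]C#N)cc1` is not yet measured. It differs from compound 2 by pentyl in place of vinyl on a saturated chain carbon bound to an oxygen next to a carbonyl group. Going by the values given here, the only measured step at this place is a 1.0-fold lower number from compound 1 to compound 2 (0.01 log units; within the scatter), which shows that swapping one small group for another on the carbamate chain left this assay unchanged. Among the compounds with values here, no measured step covers a chain of the length entering in compound 3, so the expectation for compound 3 rests on that single flat step and on the shared core. Compound 3 is therefore expected to give a number close to compound 2, with a 1.1-fold lower number from compound 2 to compound 3 (0.05 log units; within the scatter) as the estimated step and no change beyond the scatter. The estimated value for compound 3 is 45000 nM, with a range from 20000 nM to 100000 nM.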

Compound 3, concentration for total growth inhibition: 48500 nM
Estimate against measurement, compound 3: 1.1-fold (0.03 log units) below; the measured number falls inside the stated range.
By their numbers in this assay, from the lowest: compounds 3, 2 and 1 (each within the scatter of the next).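

In this assay the carbamate chain now covers a clear change in length, and the step is still flat: a 1.0-fold lower number from compound 2 to compound 3 (0.01 log units; within the scatter), with pentyl in place of vinyl on a saturated chain carbon bound to an oxygen next to a carbonyl group. Pentyl in place of isopropyl gives a 1.1-fold lower number from compound 1 to compound 3 (0.02 log units; within the scatter), so the allyl, branched and hexyl chains of these three compounds cannot be told apart by this read-out. No evidence is at hand to explain this flat behaviour.

Going by these compounds, whether a longer chain than hexyl, or a chain ending in a phenyl ring, an amine or a carboxylic acid, would move the number stays open. Also open, on these data alone, is whether the same flatness holds in other cell lines.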